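Chloro in Place of Methylsulfonyl on the Benzyl Group

The source may report more compounds than this note shows. Statements on the series, on what has been measured and on what is new or still open speak of the compounds shown alone.

Three compounds share one core and differ only in the group on the benzyl ring. Compound 1 `COc1cc2c(=O)c(C(=O)c3ccc(C)cc3)cn(Cc3ccc(Cl)c(Cl)c3)c2cc1OC` carries a dichlorobenzyl group; in an ADME assay on Huh-7 cells (Homo sapiens) for cytotoxicity (on this read-out lower numbers stand for stronger inhibition of growth and higher numbers for weaker inhibition of growth), compound 1 is recorded as "not active" (no number reported). Compound 2 `COc1cc2c(=O)c(C(=O)c3ccc(C)cc3)cn(Cc3ccc(S(C)(=O)=O)cc3)c2cc1OC` carries a methylsulfonylbenzyl group. In this assay compound 2 reaches only the assay's limit, > 50000 nM, which is a limit and not a number. Compound 2 therefore stands at the limit of > 50000 nM in this assay, at which 1 of the 2 values shown sits, while the remaining entry offers no number at all. Compound 3 `COc1cc2c(=O)c(C(=O)c3ccc(C)cc3)cn(Cc3ccc(Cl)cc3)c2cc1OC` arises from compound 2 by chloro in place of methylsulfonyl on an aromatic carbon. Among the compounds with values here, no step between two measured compounds is available, so the expected step of a number no higher from compound 2 to compound 3 (the limit leaves the size open) is none beyond the usual scatter, given that compound 2 sits at > 50000 nM. For compound 3 the estimate in this assay is 50000 nM, with a range from 20000 nM to 100000 nM, and most likely another limit rather than a number.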

Compound 3, concentration for 50% growth inhibition: 15500 nM
Compound 3: middle estimate off by 3.2-fold (0.51 log units), on the high side; the whole stated range lies above it.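

Chloro in place of methylsulfonyl gives an at least 3.2-fold lower number from compound 2 to compound 3 (0.50 log units; beyond the scatter) in this assay and brings the first number at this place on the benzyl group. The change therefore shows that the read-out responds to the group on this aromatic carbon, which neither earlier compound could show without a number. Compound 2 gives a limit and not a number, so the true size of this step stays open: the limit of > 50000 nM in this assay, at which 1 of the 3 values shown sits.

From the compounds shown here alone, compound 1 is recorded as "not active" (no number reported) and offers no number, so the step from it to compound 3 cannot be read and what the second chloro does remains unknown. Going by these compounds, whether an amine or a carboxylic acid on this carbon would give a lower or a higher number than the chloro of compound 3 also remains open.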